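Replacing carboxy with hydroxymethyl in compound 2

The source may hold more compounds than are shown below. What is called first, only, known or untested is meant among the compounds shown, and "the series" means these compounds.

In a functional assay on Z-138 cells (Homo sapiens) for inhibition, read by luminescence and CellTiter-Glo, with a stated time of 72 h (a lower number here means a stronger inhibitor, a higher number a weaker inhibitor), compound 1 (`O=C(O)c1cc(-c2ccc(Oc3ccccc3)cc2)nn1C1CCCN(C(=O)CCl)C1`) gives 2800 nM. Compound 2 (`C=CC(=O)N1CCCC(n2nc(-c3ccc(Oc4ccccc4)cc3)cc2C(=O)O)C1`) gives only a limit of the assay, > 60000 nM. Compound 3 (`C/C=C/C(=O)N1CCCC(n2nc(-c3ccc(Oc4ccccc4)cc3)cc2C(=O)O)C1`) also gives only a limit, > 60000 nM.

Compound 4 (`C=CC(=O)N1CCCC(n2nc(-c3ccc(Oc4ccccc4)cc3)cc2CO)C1`) has hydroxymethyl in place of the carboxy of compound 2 on an aromatic carbon: hydroxymethyl in place of carboxy on an aromatic carbon. Going by the values given here, no measured step touches the carboxy. All three measured steps change the group on the carbonyl carbon. Two are large and beyond the scatter: an at least 21-fold higher number from compound 1 to compound 2 (1.33 log units; beyond the scatter) and an at least 21-fold higher number from compound 1 to compound 3 (1.33 log units; beyond the scatter). The third is a step that the two limits leave unreadable from compound 2 to compound 3. These steps give no size for the new change, and the limit of > 60000 nM in this assay, at which 2 of the 3 values shown sit, means that any readable number must lie on the lower side. A moderate step to a lower number is therefore expected, though compound 4 may well remain at the limit. The expected step is an at least 4.0-fold lower number from compound 2 to compound 4 (0.60 log units; beyond the scatter). The estimate for compound 4 is 15000 nM, with an expected range of 2500 nM to 60000 nM.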

Compound 4, half-maximal inhibitory concentration: 14600 nM
For compound 4 the middle estimate is 1.0-fold (0.01 log units) above the measured one; the measured number falls inside the stated range.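

In this assay, this is the first change shown away from the carbonyl carbon, and it gives a readable number at the aromatic carbon next to the ring nitrogen: hydroxymethyl in place of carboxy brings an at least 4.1-fold lower number from compound 2 to compound 4 (0.61 log units; beyond the scatter). Compound 2 stands at a limit of the assay, > 60000 nM, and not at a number. The true size of the step therefore stays unknown, since one of its ends is such a limit: the limit of > 60000 nM in this assay, at which 2 of the 4 values shown sit.

The compounds shown leave open whether an aminomethyl group, a methyl ester or a primary amide at this carbon would give a lower or a higher number than hydroxymethyl. They also leave open whether hydroxymethyl would have a similar effect with chloromethyl on the carbonyl carbon, the group carried by compound 1.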